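Swapping the aryl group on a thiosemicarbazone: compound 1 to 4

The source may report more compounds than this note shows. Statements on the series, on what has been measured and on what is new or still open speak of the compounds shown alone.

This set of thiosemicarbazones was tested in a functional assay on SGC-7901 cells (Homo sapiens) for antiproliferative activity, read by sulforhodamine B assay, with a stated time of 72 h; a higher number here means a weaker inhibitor, a lower number a stronger inhibitor. Compound 1, with structure `Fc1ccccc1NC(=S)N/N=C/c1ccc2ccccc2n1`, stands at the limit of this assay: it gives > 100000 nM, which is a limit and not a number. Compound 2, with structure `NC(=S)N/N=C/c1ccc2cccnc2n1`, likewise reaches only a limit of > 100000 nM in this assay. Among the compounds with values here, compound 3, with structure `CN(C)C(=S)N/N=C/c1cnc2ccccc2n1`, is the one compound with a measured number, giving 170 nM in this assay. Thus the limit of > 100000 nM in this assay, at which 2 of the 3 values shown sit, marks where compound 1 sits, at the weak end of the series.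

Compound 4, with structure `COc1cccc(NC(=S)N/N=C/c2ccc3ccccc3n2)c1`, has not yet been measured. It differs from compound 1 in one place: 3-methoxyphenyl in place of 2-fluorophenyl on an amide-type nitrogen. Within the data shown here, no step between measured compounds is known, so the effect of this swap is open. Compound 4 is expected to stay near the limit, so the step of an at least 1.2-fold lower number from compound 1 to compound 4 (0.09 log units; that floor lies within the scatter) is estimated as small and toward stronger inhibition at most. The estimate for compound 4 in this assay is 80000 nM, within a range from 10000 nM to 200000 nM.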

Compound 4, half-maximal inhibitory concentration: 79400 nM
Compound 4: the middle estimate sits 1.0-fold (0.00 log units) above what was measured; measured number inside the range.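

Within the data shown here, replacing the aryl group gives the first step at this amide-type nitrogen, with 3-methoxyphenyl in place of 2-fluorophenyl: an at least 1.2-fold lower number from compound 1 to compound 4 (0.10 log units; that floor lies within the scatter). Compound 4 therefore brings the series its first measured number on this core, showing that this aryl change can bring a value inside the range of this assay, but the step cannot be called a real gain. Its true size stays unknown because compound 1 stands at a limit, which is not a number: the limit of > 100000 nM in this assay, at which 2 of the 4 values shown sit.

From the compounds shown here alone, whether a small alkyl group, a longer chain such as butyl, or a phenyl ring bearing a carboxylic acid would move the value further at this nitrogen remains open. Compound 4 differs from compound 3 in more than one place, so the compounds shown cannot say which feature accounts for the value of compound 3, 170 nM.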